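Methyl for chlorine in the aryl ester side chain

This account rests on a few compounds, and the source may have more. Where it says the series, first, only, none or still open, it means among the compounds named here.

Measured compounds:
compound 1, `COC(=O)c1cc(Cl)ccc1OC(=O)COc1cc(O)c2c(=O)cc(-c3ccccc3)oc2c1`, 3740 nM in a functional assay on cells (T-cell, Mus musculus, strain BALB/c) for inhibition, read by MTT assay, with a stated time of 72 h; on this read-out lower numbers stand for stronger inhibition and higher numbers for weaker inhibition
compound 2, `COC(=O)c1ccc(Cl)cc1OC(=O)COc1cc(O)c2c(=O)cc(-c3ccccc3)oc2c1`, 12400 nM in this assay

For the measured compounds named here, compound 2 gives the higher of the two numbers so far in this assay; the only step that relates it to another compound is a 3.3-fold higher number from compound 1 to compound 2 (0.52 log units; beyond the scatter), a modest change that moved compound 2 above compound 1 by more than the usual scatter. Compound 3, `COC(=O)c1c(C)cccc1OC(=O)COc1cc(O)c2c(=O)cc(-c3ccccc3)oc2c1`, has not yet been measured. It differs from compound 2 in one place: a group of 11 heavy atoms (9 carbon, 2 oxygen; one six-membered aromatic ring of carbon only) in place of a group of 11 heavy atoms (8 carbon, 2 oxygen, 1 chlorine; one six-membered aromatic ring of carbon only), on an oxygen next to a carbonyl group. The entering group has no common name and carries no chlorine. Going by the values given here, no measured step involves this entering group, so the only guidance is the step of a 3.3-fold higher number from compound 1 to compound 2 (0.52 log units; beyond the scatter), which shows that rearranging substituents on the same aryl ester moves the number only modestly. A comparably sized change is therefore expected here, with no firm direction. The estimated step of a 1.6-fold lower number from compound 2 to compound 3 (0.19 log units; within the scatter) for compound 3 is expected to stay small. Compound 3 is expected to give about 8000 nM in this assay, within a range from 2500 nM to 25000 nM.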

Compound 3, half-maximal inhibitory concentration: 37200 nM
Estimate against measurement, compound 3: 4.7-fold (0.67 log units) below, outside the stated range (above it).
By their numbers in this assay, from the lowest: compound 1; then compound 2; then compound 3.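

The earlier pair showed only that a chlorine-bearing aryl ester responds to a rearrangement of its substituents; compound 3 shows that a group with no chlorine, with 9 carbon against 8 carbon and the same count of 11 heavy atoms, also moves the number beyond the scatter, here with a 3.0-fold higher number from compound 2 to compound 3 (0.48 log units; beyond the scatter) in this assay. Set against the other chlorine-bearing ester, the change is larger, with a 9.9-fold higher number from compound 1 to compound 3 (1.00 log units; beyond the scatter), so compound 3 is the weakest inhibitor of the three, and this one place on the side chain alone spans all of the differences seen in this series. Nothing measured here accounts for these shifts.

The compounds shown leave open whether a fluorine or a methoxy group in place of the chlorine would hold the number near that of compound 1, or whether the chlorine itself matters. They also leave open how a free carboxylic acid or an amide in place of the methoxycarbonyl group would read in this assay.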